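Swapping the sulfonamide for a fluorinated chain on the shared core

A few compounds are considered here, and "the series" means these few. Any claim that something is new, unique, unknown or untested is made for them only; others in the source may bear on it.

Compound 1 `CCSCCC12CCC(c3nnc(-c4ccccc4C(F)(F)F)n3C)(CC1)CC2`: 79%
Compound 2 `Cn1c(-c2ccccc2C(F)(F)F)nnc1C12CCC(CCS(=O)(=O)C(C)(C)C)(CC1)CC2`: 65%
Compound 3 `Cn1c(-c2ccccc2C(F)(F)F)nnc1C12CCC(CNS(C)(=O)=O)(CC1)CC2`: 73%

Of the compounds shown here, three sharing one core have been measured in a functional assay on the whole organism (strain ICR) for inhibition, with Mus musculus as the target, with a stated time of 4 h, at a dose of 10 mg/kg by the oral route; on this read-out higher numbers stand for more inhibition at the one dose given (going by the name of the read-out) and lower numbers for less inhibition. Compound 1 gives 79%, compound 2 gives 65% and compound 3 gives 73%. Among the measured compounds shown here, compound 3 sits between the other two: a number 6 percentage points lower from compound 1 to compound 3 (within the scatter), and a number 8 percentage points higher from compound 2 to compound 3 (within the scatter), so on these numbers it is not separable from either neighbour, while a number 14 percentage points lower from compound 1 to compound 2 (beyond the scatter) is the only step that clears the scatter.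

Compound 4 `Cn1c(-c2ccccc2C(F)(F)F)nnc1C12CCC(CCCC(C)(F)F)(CC1)CC2` has not yet been measured. It differs from compound 3 in one place: a group of 6 heavy atoms (4 carbon, 2 fluorine; no ring) in place of a group of 5 heavy atoms (1 carbon, 1 nitrogen, 2 oxygen, 1 sulfur; no ring), on a saturated chain carbon bound to a saturated ring carbon

For the measured compounds named here, the steps that bear on this change are those at the same place. From compound 1 to compound 3 a group without a hydrogen-bond donor was replaced by one with a donor, and a number 6 percentage points lower from compound 1 to compound 3 (within the scatter). From compound 2 to compound 3 the result was a number 8 percentage points higher from compound 2 to compound 3 (within the scatter). Both of these changes at this position stayed within the scatter, and only the (tert-butyl)sulfonyl group of compound 2 moved the number beyond it. The change to compound 4 removes the donor and acceptors again, which is closer in kind to compound 1 than to compound 2, so the expected step is small: a number 2 percentage points higher from compound 3 to compound 4 (within the scatter) is expected, with no clear direction.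

Compound 4 is therefore estimated to give 75% in this assay, with a likely range from 60% to 88%.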

Compound 4, a percentage reported as inhibition, in the whole organism at one dose (the size of the read-out at that dose, not a potency): 99%
The estimate for compound 4 lay 24 percentage points below the measured number, and the stated range ends below it.
By their numbers in this assay, from the lowest: compounds 2, 3 and 1 (each within the scatter of the next, the first and the last beyond it); then compound 4.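

In this assay, replacing methanesulfonamido with a group that has 0 hydrogen-bond donors and 0 hydrogen-bond acceptors gives a number 26 percentage points higher from compound 3 to compound 4 (beyond the scatter), whereas the earlier changes leading to compound 3 at this saturated chain carbon stayed within the scatter. The new group also separates clearly from the sulfur-containing chains, with a number 20 percentage points higher from compound 1 to compound 4 (beyond the scatter) and a number 34 percentage points higher from compound 2 to compound 4 (beyond the scatter), so compound 4 is the highest of the four and this position can move the read-out more than the first three compounds suggested. The data offer no measured explanation for this rise, and the read-out gives the size of the effect at one dose rather than a potency.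

The compounds shown leave open whether the two fluorine atoms matter or whether the carbon chain alone accounts for the step, a question that a plain butyl chain at the same place could help settle. A longer chain, an amine or a carboxylic acid there would show how widely the result extends beyond these four groups.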